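Stereochemical inversion in the cyclobutane-linked aminopyrimidine series

The compounds below may be only part of what the source reports. "The series", "measured", "known", "first", "only" and "open" are said of these compounds alone.

Compound 2 `CC1(C)[C@H](O)C[C@H]1Nc1nc(NCc2cnccc2C(F)(F)F)ncc1C#N` gives 4500 nM in an assay on isolated protein for inhibition of protein kinase C delta type (Homo sapiens), read by TR-FRET, with a stated time of 2 h (a lower number here means a stronger inhibitor, a higher number a weaker inhibitor), the higher of the two numbers measured, with compound 1 `CC1(C)[C@@H](O)C[C@H]1Nc1nc(NCc2cnccc2C(F)(F)F)ncc1C#N` at 600 nM as its nearest neighbour. The step of a 7.5-fold higher number from compound 1 to compound 2 (0.88 log units; beyond the scatter) rests solely on (the fact that compounds 1 and 2 differ only in the configuration as drawn).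

Compound 3 `CC1(C)[C@H](O)C[C@@H]1Nc1nc(NCc2cnccc2C(F)(F)F)ncc1C#N` is not yet measured. Relative to compound 2, (the two compounds have the same atoms and bonds and differ only in configuration as drawn: 1 of 2 stereo elements differ; a stereocentre at a saturated ring carbon is drawn R in compound 2 and S in compound 3); nothing leaves and nothing enters, and the stereo element now changed is the other of the two. Among the compounds with values here, the only measured step of the same kind, a single inversion of a ring stereocentre, is a 7.5-fold higher number from compound 1 to compound 2 (0.88 log units; beyond the scatter), which was modest but beyond the scatter, so a step of comparable size is expected here, in either direction, without a firm sign from the data. For compound 3 the expectation is 2500 nM, within 400 nM to 15000 nM, meaning a 1.8-fold lower number from compound 2 to compound 3 (0.26 log units; within the scatter) as the expected step.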

Compound 3, half-maximal inhibitory concentration: 8500 nM
Beside the measured number, compound 3's estimate is 3.4-fold (0.53 log units) below it; measured number inside the range.
By their numbers in this assay, from the lowest: compound 1; then compounds 2 and 3 (each within the scatter of the next).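

In this assay inversion of the other stereocentre stays within the scatter (a 1.9-fold higher number from compound 2 to compound 3 (0.28 log units; within the scatter)), so the sensitivity seen at the first stereocentre does not recur at this one when starting from compound 2. Inverting both stereocentres gives the mirror-image pair and the largest separation in the series (a 14-fold higher number from compound 1 to compound 3 (1.15 log units; beyond the scatter)), and compound 1 is the strongest of the three, with its steps to both others beyond the scatter. Atoms and bonds stay constant, so this separation rests on configuration alone: the fact that compounds 1 and 3 differ only in the configuration as drawn

On these data alone, the fourth arrangement of the two stereocentres remains open, including whether it would stand with compound 1 or with compounds 2 and 3. Also open, as far as these compounds go, is whether a methoxy group or a carboxylic acid in place of the hydroxyl would preserve the preference for the configuration of compound 1.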